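A few compounds are considered here, and "the series" means these few. Any claim that something is new, unique, unknown or untested is made for them only; others in the source may bear on it.

Series notes. Compound 1 `O=C(NCc1ccc(CNS(=O)(=O)c2ccc3c(c2)CCO3)cc1)c1scc2c1OCCO2` and compound 2 `Cc1cc(C(=O)NCc2ccc(CNS(=O)(=O)c3ccc4c(c3)CCO4)cc2)n(C)n1` carry one sulfonyl substituent, compound 3 `O=C(NCc1ccc(CNS(=O)(=O)c2cccc(F)c2)cc1)c1cc2ccccn2n1` another. In an assay on cells for inhibition of C-X-C chemokine receptor type 4 (Homo sapiens), with a stated time of 22 h, tested at 100 nM (on this read-out lower numbers stand for less inhibition and higher numbers for more inhibition at the one concentration tested (going by the name of the read-out)), compound 1 gives 68%, compound 2 is reported only as "active" (no number reported) without a number, and compound 3 gives 40%, the lowest of the two numbers shown and a gap from compound 1 that lies beyond the usual scatter. Compound 4 `O=C(NCc1ccc(CNS(=O)(=O)c2ccc3c(c2)CCO3)cc1)c1cc2ccccn2n1` keeps the amide side of compound 3 and changes the sulfonyl side: a group of 9 heavy atoms (8 carbon, 1 oxygen; one five-membered non-aromatic ring with 1 hetero atom, one six-membered aromatic ring of carbon only) in place of a group of 7 heavy atoms (6 carbon, 1 fluorine; one six-membered aromatic ring of carbon only), on a sulfonyl sulfur. For the measured compounds named here, no measured pair shows this single change on its own. For compound 4 an upward step in this assay is expected, a number 15 percentage points higher from compound 3 to compound 4 (beyond the scatter), because compound 1 gives 68% with the same entering sulfonyl substituent. Compound 4 is estimated at 55%, in the range 35% to 75%.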

Compound 4, a percentage reported as inhibition, at one concentration (the size of the read-out at that concentration, not a potency): 40%
The estimate for compound 4 lay 15 percentage points above the measured number; the range from low to high includes it.
By their numbers in this assay, from the lowest: compounds 3 and 4 (each within the scatter of the next); then compound 1.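

In this assay, the sulfonyl change alone gives no change at the digits printed from compound 3 to compound 4 (within the scatter), so with this amide side the 3-fluorophenyl group and the entering group read alike on a sulfonyl sulfur. With the sulfonyl substituent held, the change on a carbonyl carbon gives a number 28 percentage points lower from compound 1 to compound 4 (beyond the scatter), so the amide side does move this read-out. Nothing measured here explains either result.

Steps to compound 2 cannot be read, as it carries no number. Open, going by these compounds, is whether the sulfonyl result holds with the amide side of compound 1, and how a sulfonyl sulfur carrying a simple methyl group or an aminophenyl group would read.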